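Chloro on the amide-side phenyl of compound 3

The source may hold more compounds than are shown below. What is called first, only, known or untested is meant among the compounds shown, and "the series" means these compounds.

Of the compounds shown here, three sharing one core have been measured in a functional assay on CCRF-CEM cells (Homo sapiens) for cytotoxicity; on this read-out lower numbers stand for stronger inhibition and higher numbers for weaker inhibition. Compound 1 `CC(=O)c1ccc(NC(=O)/C=C/C(=O)N2C/C(=C\c3ccccc3)C(=O)/C(=C/c3ccccc3)C2)cc1` gives 1700 nM in this assay. Compound 2 `Cc1ccc(NC(=O)/C=C/C(=O)N2C/C(=C\c3ccccc3)C(=O)/C(=C/c3ccccc3)C2)cc1C` gives 7100 nM, and compound 3 `O=C(/C=C/C(=O)N1C/C(=C\c2ccccc2)C(=O)/C(=C/c2ccccc2)C1)Nc1ccccc1` gives 1100 nM. Compound 3 holds the lowest of the three numbers, yet its gap to compound 1, a 1.5-fold lower number from compound 1 to compound 3 (0.19 log units; within the scatter), sits within the scatter, while its gap to compound 2, a 6.5-fold lower number from compound 2 to compound 3 (0.81 log units; beyond the scatter), lies beyond it.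

Compound 4 `O=C(/C=C/C(=O)N1C/C(=C\c2ccccc2)C(=O)/C(=C/c2ccccc2)C1)Nc1ccc(Cl)cc1` differs from compound 3 by chloro in place of hydrogen on an aromatic carbon. For the measured compounds named here, no measured step introduces a chloro group, so the two steps that change the same phenyl on the amide nitrogen are the only guide: removing acetyl left the number within the scatter, and exchanging 3,4-dimethylphenyl for phenyl gave a modest fall. Going by these compounds, neither points to a large move for a single chlorine, and the direction stays open. Compound 4 is therefore expected to give 1200 nM in this assay, with a range from 500 nM to 3000 nM. That estimate means a step of a 1.1-fold higher number from compound 3 to compound 4 (0.04 log units; within the scatter), expected to remain within the scatter.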

Compound 4, half-maximal inhibitory concentration: 840 nM
For compound 4 the middle estimate is 1.4-fold (0.15 log units) above the measured one, and the stated range covers the measured number.
By their numbers in this assay, from the lowest: compounds 4, 3 and 1 (each within the scatter of the next, the first and the last beyond it); then compound 2.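

In this assay, chloro on an aromatic carbon para to a large group leaves compound 4 close to its unsubstituted parent, with a 1.3-fold lower number from compound 3 to compound 4 (0.12 log units; within the scatter), so this position accepts a single chlorine without a step beyond the scatter. The earlier compounds shown here showed only that removing acetyl or the two methyl groups left the parent's number where it was printed, whereas this change gives a 2.0-fold lower number from compound 1 to compound 4 (0.31 log units; beyond the scatter) and an 8.5-fold lower number from compound 2 to compound 4 (0.93 log units; beyond the scatter), placing compound 4 beyond the scatter of both substituted neighbours, while compound 3 is beyond the scatter of compound 2 alone. No supporting data are available to explain these differences.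

Going by these compounds, whether a methoxy group, an amine or a carboxylic acid at this position would stay as close to compound 3 remains open. So does the effect of chloro at another place on the same ring.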